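Trifluoromethyl in Place of Chloro on Compound 1

This account rests on a few compounds, and the source may have more. Where it says the series, first, only, none or still open, it means among the compounds named here.

Of the compounds shown here, three that share one core have been measured in a functional assay on HT-29 cells (Homo sapiens) for cytotoxicity, read by MTT assay, with a stated time of 72 h; on this read-out lower numbers stand for stronger inhibition and higher numbers for weaker inhibition. Compound 1 `O=C(CN1CCN(c2nnc(Cc3ccncc3)c3ccccc23)CC1)Nc1ccc(F)c(Cl)c1` gives 880 nM, the lowest of the three numbers, and it stands apart from the other two by margins that lie well beyond the usual scatter. Compound 2 `Cc1ccc(F)cc1NC(=O)CN1CCN(c2nnc(Cc3ccccc3)c3ccccc23)CC1` gives 171000 nM, and compound 3 `Cc1ccccc1NC(=O)CN1CCN(c2nnc(Cc3ccccc3)c3ccccc23)CC1` gives 113000 nM. Within the data shown here, the only pair among them that differs in a single place is compound 2 and compound 3, and that step, a 1.5-fold lower number from compound 2 to compound 3 (0.18 log units; within the scatter), stays within the scatter.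

Compound 4 `O=C(CN1CCN(c2nnc(Cc3ccncc3)c3ccccc23)CC1)Nc1ccc(F)c(C(F)(F)F)c1` is the next compound to be measured in this assay. It differs from compound 1 in one place: trifluoromethyl in place of chloro on an aromatic carbon. Among the measured compounds shown here, no measured pair in this set shows this particular exchange. For the measured compounds named here, the one recorded step concerns a different group, fluoro to hydrogen, and it was too small to register beyond the scatter; it offers no direct guide to how chloro against trifluoromethyl will read. With nothing pointing either way, the step from compound 1 to compound 4 is expected to be small, a 1.1-fold higher number from compound 1 to compound 4 (0.06 log units; within the scatter), and not beyond the scatter. Compound 4 is therefore estimated at 1000 nM, within a range from 300 nM to 3500 nM.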

Compound 4, half-maximal inhibitory concentration: 1110 nM
Compound 4: the middle estimate sits 1.1-fold (0.05 log units) below what was measured; the measured number falls inside the stated range.
By their numbers in this assay, from the lowest: compounds 1 and 4 (each within the scatter of the next); then compounds 3 and 2 (each within the scatter of the next).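

In this assay, the exchange of chloro for trifluoromethyl on an aromatic carbon, ortho to a fluoro group, gives a 1.3-fold higher number from compound 1 to compound 4 (0.10 log units; within the scatter), so compound 1 and compound 4 cannot be told apart on this read-out. Among these compounds, this is the first direct reading at this position, since the only earlier single-place step concerned fluoro and hydrogen on a different aryl group, and it shows that the substituent here can grow from 1 heavy atom to 4 heavy atoms with the number staying within the scatter. The material shown holds nothing that bears on the reason for this result.

One exchange does not show how far this position stays indifferent: an amine, a carboxylic acid or a longer alkyl chain in place of chloro could read quite differently, and the compounds shown give no reading for them. The wide gap between compounds 1 and 4 and compounds 2 and 3 also stays unassigned, as those compounds differ from compound 1 in more than one place and no single change can be held responsible for it.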